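Triazole Aromatase Inhibitors: From Phenyl to Chlorophenoxymethyl

A few compounds are considered here, and "the series" means these few. Any claim that something is new, unique, unknown or untested is made for them only; others in the source may bear on it.

Compound 1 `c1ccc(C(c2ccccc2)n2cc(C3CCCCC3)nn2)cc1` and compound 2 `c1ccc(-c2cn(C(c3ccccc3)c3ccccc3)nn2)cc1` share one core. In an assay on isolated protein for inhibition of Aromatase (Homo sapiens), read by fluorescence and colorimetric assay, with a stated time of 30 min (a higher number here means a weaker inhibitor, a lower number a stronger inhibitor), compound 1 gives 13700 nM, and compound 2 gives 12900 nM; the step of a 1.1-fold lower number from compound 1 to compound 2 (0.03 log units; within the scatter) lies within the scatter, so compound 2 stands on a number indistinguishable from that of compound 1. Compound 3 `Clc1ccc(OCc2cn(C(c3ccccc3)c3ccccc3)nn2)cc1` carries (4-chlorophenoxy)methyl in place of phenyl on an aromatic carbon. Within the data shown here, no measured step bears directly on this change; the only comparison at this position, cyclohexyl against phenyl, moved nothing beyond the scatter. The step in this assay is therefore expected to be small and uncertain, a 1.4-fold lower number from compound 2 to compound 3 (0.16 log units; within the scatter). Compound 3 is estimated at 9000 nM, between 2500 nM and 30000 nM.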

Compound 3, half-maximal inhibitory concentration: 13400 nM
Estimate against measurement, compound 3: 1.5-fold (0.17 log units) below; low and high end bracket the measured number.
By their numbers in this assay, from the lowest: compounds 2, 3 and 1 (each within the scatter of the next).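

In this assay (4-chlorophenoxy)methyl at this position gives a 1.0-fold higher number from compound 2 to compound 3 (0.02 log units; within the scatter) and a 1.0-fold lower number from compound 1 to compound 3 (0.01 log units; within the scatter) on the shared core. The position thus takes a group with an oxygen, a chlorine and one hydrogen-bond acceptor, where phenyl and cyclohexyl have none of these, with no change beyond the scatter. No evidence at hand accounts for this flat result.

The compounds shown leave open whether an amine or a carboxylic acid at this position would move the number at all. They also leave open whether a shorter link than the one in (4-chlorophenoxy)methyl would matter.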